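The compounds below may be only part of what the source reports. "The series", "measured", "known", "first", "only" and "open" are said of these compounds alone.

Compound 1 `COc1ccc(S(=O)(=O)N(Cc2cc(F)cc(F)c2)[C@H](C)C(=O)NO)cc1`: 140 nM
Compound 2 `COc1ccc(S(=O)(=O)N(Cc2sccc2Oc2ccccc2)[C@H](C)C(=O)NO)cc1`: 40 nM

In an assay on isolated protein for inhibition of bone morphogenetic protein 1 (Homo sapiens) (a higher number here means a weaker inhibitor, a lower number a stronger inhibitor), compound 1 gives 140 nM, while compound 2 gives 40 nM. Compound 1 therefore holds the higher of the two numbers, and its gap to compound 2 lies beyond the scatter. Compound 3 `COc1ccc(S(=O)(=O)N(Cc2cnc(Cl)s2)[C@H](C)C(=O)NO)cc1` has not yet been measured. It differs from compound 1 in one place: 2-chloro-1,3-thiazol-5-yl in place of 3,5-difluorophenyl on a saturated chain carbon bound to a sulfonamide nitrogen. Among the measured compounds shown here, no measured pair shows this exact change. In this assay the step is expected to be small, if anything toward a higher number: a 1.4-fold higher number from compound 1 to compound 3 (0.15 log units; within the scatter). Compound 3 is accordingly estimated at 200 nM, within a range from 70 nM to 600 nM.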

Compound 3, half-maximal inhibitory concentration: 180 nM
The estimate for compound 3 lay 1.1-fold (0.05 log units) above the measured number; measured number inside the range.
By their numbers in this assay, from the lowest: compound 2; then compounds 1 and 3 (each within the scatter of the next).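

In this assay, 2-chloro-1,3-thiazol-5-yl in place of 3,5-difluorophenyl on a saturated chain carbon bound to a sulfonamide nitrogen gives a 1.3-fold higher number from compound 1 to compound 3 (0.11 log units; within the scatter), so the two groups cannot be told apart here. At this position, a five-membered aromatic ring with 2 hetero atoms and 2 hydrogen-bond acceptors thus matches a six-membered aromatic ring of carbon only with 0 acceptors. No measurement at hand bears on this outcome. As far as these compounds go, it remains open how a cyclohexyl group or an aminomethyl group would fare at this position, and whether replacing the chlorine of compound 3 with hydrogen or a methyl group would shift the number.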